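The source may report more compounds than this note shows. Statements on the series, on what has been measured and on what is new or still open speak of the compounds shown alone.

Three compounds of the series carry numbers in a functional assay on PC-3 cells (Homo sapiens) for cytotoxicity, read by MTT assay, with a stated time of 48 h; a lower number here means a stronger inhibitor, a higher number a weaker inhibitor. Compound 1 `CC1=NN(C(=O)COc2ccc(Cl)cc2)C(c2ccccc2O)C1` gives 38800 nM. Compound 2 `Cc1ccc(C(=O)N2N=C(c3cc4ccccc4oc3=O)CC2c2ccccc2)cc1` gives 13200 nM, and compound 3 `O=C(c1ccccc1Cl)N1N=C(c2cc3ccccc3oc2=O)CC1c1ccccc1` gives 6370 nM, the lowest of the three. Among the compounds with values here, the one measured step between two compounds that differ in a single place is a 2.1-fold lower number from compound 2 to compound 3 (0.32 log units; beyond the scatter). Within the data shown here, compound 3 stands furthest from compound 1, but those two differ in several places and no single step is counted between them.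

Compound 4 `CCNCC(=O)N1N=C(c2cc3ccccc3oc2=O)CC1c1ccccc1` has not yet been measured in this assay. It differs from compound 3 by (ethylamino)methyl in place of 2-chlorophenyl on a carbonyl carbon. Among the measured compounds shown here, the only measured step touching this carbonyl carbon is a 2.1-fold lower number from compound 2 to compound 3 (0.32 log units; beyond the scatter), which exchanged one six-membered aromatic ring of carbon only for another and moved the number modestly. For the measured compounds named here, no measured step exchanges a ring at this place for (ethylamino)methyl, with its 1 hydrogen-bond donor and 1 hydrogen-bond acceptor, so the direction of the coming step rests on little. Because a 2.1-fold lower number from compound 2 to compound 3 (0.32 log units; beyond the scatter) was modest, the expectation for compound 4 in this assay is a number near that of compound 3 or somewhat higher, the step being estimated at a 1.9-fold higher number from compound 3 to compound 4 (0.28 log units; within the scatter). The estimate for compound 4 in this assay is 12000 nM, within a range from 4000 nM to 40000 nM.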

Compound 4, half-maximal inhibitory concentration: 5580 nM
Beside the measured number, compound 4's estimate is 2.2-fold (0.33 log units) above it, within the range that was stated.
By their numbers in this assay, from the lowest: compounds 4 and 3 (each within the scatter of the next); then compound 2; then compound 1.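

In this assay, the carbonyl carbon whose other neighbour is the amide-type nitrogen in a ring now has a measured exchange that goes beyond one six-membered aromatic ring for another (a 1.1-fold lower number from compound 3 to compound 4 (0.06 log units; within the scatter)). Here 2-chlorophenyl and (ethylamino)methyl cannot be told apart, although the entering group has no ring, 4 heavy atoms against 7, and 1 hydrogen-bond donor and 1 hydrogen-bond acceptor where the leaving group has neither. Measured from the 4-methylphenyl compound, the same exchange gives a modest step beyond the scatter (a 2.4-fold lower number from compound 2 to compound 4 (0.37 log units; beyond the scatter)), so among these three compounds an aromatic ring on this carbonyl carbon is not needed to hold the number, and no measurement shown offers a reason for this.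

The compounds shown do not separate the part played by the nitrogen of (ethylamino)methyl from that of the chain, which a plain propyl group at this carbonyl carbon would address. Also open, going by these compounds, is how far this position accepts other changes, such as a dimethylamino group, a longer chain carrying the amine, or a carboxylic acid.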